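The source may hold more compounds than are shown below. What is called first, only, known or untested is meant among the compounds shown, and "the series" means these compounds.

Compound 3 `Cc1ccc(-c2cc(Cl)cc(Cl)c2/C=C/[C@@H]2C[C@@H](O)CC(=O)O2)cc1` gives 190 nM in an assay for inhibition of 3-hydroxy-3-methylglutaryl-coenzyme A reductase (Rattus norvegicus) (on this read-out lower numbers stand for stronger inhibition and higher numbers for weaker inhibition), the highest number of the three measured compounds. Compound 1 `Cc1cc(F)ccc1-c1cc(Cl)cc(Cl)c1/C=C/[C@@H]1C[C@@H](O)CC(=O)O1` gives 36 nM and compound 2 `O=C1C[C@H](O)C[C@@H](/C=C/c2c(Cl)cc(Cl)cc2-c2ccccc2)O1` gives 80 nM in this assay. The step to compound 4 `Cc1ccccc1-c1cc(Cl)cc(Cl)c1/C=C/[C@@H]1C[C@@H](O)CC(=O)O1` is 2-methylphenyl in place of 4-methylphenyl on an aromatic carbon. For the measured compounds named here, two measured steps bear on it: a 2.4-fold higher number from compound 2 to compound 3 (0.38 log units; beyond the scatter) shows the 4-methyl group costing potency, while a 2.2-fold higher number from compound 1 to compound 2 (0.35 log units; beyond the scatter) shows that a ring bearing a 2-methyl group, together with fluorine, outperforms plain phenyl. Moving the methyl group is therefore expected to lower the number in this assay, with a 3.2-fold lower number from compound 3 to compound 4 (0.50 log units; beyond the scatter) as the estimated step. Compound 4 is expected to reach about 60 nM, within a range of 25 nM to 150 nM.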

Compound 4, half-maximal inhibitory concentration: 370 nM
Compound 4: the middle estimate sits 6.2-fold (0.79 log units) below what was measured, and the stated range ends below it.
By their numbers in this assay, from the lowest: compound 1; then compound 2; then compounds 3 and 4 (each within the scatter of the next).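

The shift of the methyl group gives a 1.9-fold higher number from compound 3 to compound 4 (0.29 log units; within the scatter) in this assay and so the 2-methylphenyl and 4-methylphenyl placements cannot be told apart. Against plain phenyl, the 2-methyl group alone gives a 4.6-fold higher number from compound 2 to compound 4 (0.67 log units; beyond the scatter) and so does not account for the better number of compound 1. Removing fluoro gives a 10-fold higher number from compound 1 to compound 4 (1.01 log units; beyond the scatter) and this shows that, within 4-fluoro-2-methylphenyl, the gain depends on the fluoro group. Nothing measured here explains these steps.

The compounds shown leave open how fluoro would read on the phenyl ring without any methyl, and whether methoxy or ethyl in place of methyl would behave as methyl does.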